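This account rests on a few compounds, and the source may have more. Where it says the series, first, only, none or still open, it means among the compounds named here.

Measured so far in a toxicity assay on HepG2 cells (Homo sapiens) for inhibition, read by CellTiter-Glo, with a stated time of 48 h; a higher number here means a weaker inhibitor, a lower number a stronger inhibitor:

compound 1 `COc1ccc2nc(C)cc(OCC(=O)Nc3cc(C)cc(C)c3)c2c1` — 20000 nM
compound 2 `Cc1cc(C)cc(NC(=O)COc2cc(C)nc3ccc(F)cc23)c1` — 63100 nM

Compound 1 has the lowest number of the two; the nearest to it is compound 2, reached by a 3.2-fold higher number from compound 1 to compound 2 (0.50 log units; beyond the scatter), a step made by fluoro in place of methoxy on an aromatic carbon of the shared core.

Compound 3 `COc1ccc2nc(C)cc(OCC(=O)Nc3c(C)cncc3C)c2c1` is not yet measured in this assay. It differs from compound 1 in 3,5-dimethylpyridin-4-yl in place of 3,5-dimethylphenyl on an amide-type nitrogen. Within the data shown here, the only measured step concerns a substituent on the core, not the group on the amide-type nitrogen, so it does not bear on this change; no measured pair shows what exchanging the aryl group on the amide-type nitrogen does here. The expectation for compound 3 therefore rests on compound 1 alone, with no step beyond the scatter expected in either direction and a wide range allowed.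

Compound 3 is estimated at 25000 nM in this assay, within 8000 nM to 80000 nM, that is an expected 1.3-fold higher number from compound 1 to compound 3 (0.10 log units; within the scatter).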

Compound 3, half-maximal inhibitory concentration: 12600 nM
The estimate for compound 3 lay 2.0-fold (0.30 log units) above the measured number; the measured number falls inside the stated range.
By their numbers in this assay, from the lowest: compounds 3 and 1 (each within the scatter of the next); then compound 2.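

In this assay the group on the amide-type nitrogen now has a measured exchange: 3,5-dimethylpyridin-4-yl in place of 3,5-dimethylphenyl gives a 1.6-fold lower number from compound 1 to compound 3 (0.20 log units; within the scatter), so compound 1 and compound 3 cannot be told apart at this position. The entering group carries a ring nitrogen that the leaving group lacks, yet this step stays within the scatter, whereas the step on the core, a 3.2-fold higher number from compound 1 to compound 2 (0.50 log units; beyond the scatter), lies beyond it; among the compounds shown, only the core substituent has so far produced a step beyond the scatter. Nothing at hand offers an explanation for the result on the amide-type nitrogen.

As far as these compounds go, it remains open whether a larger departure at this position, such as an unsubstituted phenyl, a saturated cyclohexyl ring, or an aryl group carrying an amine or a carboxylic acid, would give a step beyond the scatter. From the compounds shown here alone, it is also open whether fluoro in place of methoxy on the core gives a comparable step when 3,5-dimethylpyridin-4-yl stands on the amide-type nitrogen.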